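A chloro in place of hydrogen on compound 3

The compounds below may be only part of what the source reports. "The series", "measured", "known", "first", "only" and "open" are said of these compounds alone.

Three compounds measured in an ADME assay on liver (Mesocricetus auratus) for metabolic stability, using microsomes (a higher number here means faster removal of the compound, a lower number slower removal), so far
- compound 1 `O=C(Nc1cc(-c2ccccn2)n[nH]1)N1CCC(c2cccc(F)c2)CC1` gives 207 mL.min-1.g-1
- compound 2 `N#Cc1ccc(OC2CCN(C(=O)Nc3cc(-c4ccccn4)n[nH]3)CC2)cc1` gives 30.8 mL.min-1.g-1
- compound 3 `O=C(Nc1cc(-c2ccccn2)n[nH]1)N1CCC(c2ccccc2)CC1` gives 216 mL.min-1.g-1

In this assay compound 3 stands level with compound 1 and well apart from compound 2. The numbers show a 1.0-fold higher number from compound 1 to compound 3 (0.02 log units; within the scatter) and also a 7.0-fold higher number from compound 2 to compound 3 (0.85 log units; beyond the scatter) as the gap on the other side.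

The next compound is compound 4 `O=C(Nc1cc(-c2ccccn2)n[nH]1)N1CCC(c2cccc(Cl)c2)CC1` and it differs from compound 3 by chloro in place of hydrogen on an aromatic carbon, meta to a large group chloro in place of hydrogen on an aromatic carbon on the same phenyl.

For the measured compounds named here, the closest precedent is compound 1, with a 1.0-fold higher number from compound 1 to compound 3 (0.02 log units; within the scatter) for hydrogen in place of fluoro on an aromatic carbon. That exchange moved the number by no more than the scatter. The two larger steps, a 6.7-fold lower number from compound 1 to compound 2 (0.83 log units; beyond the scatter) and a 7.0-fold higher number from compound 2 to compound 3 (0.85 log units; beyond the scatter), replace the whole aryl group with 4-cyanophenoxy or back, so they say little about a single halogen. Going by the values given here, no chloro compound has been measured, so the fluoro case is only a guide.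

The expected change is a 1.0-fold higher number from compound 3 to compound 4 (0.01 log units; within the scatter) and so none beyond the scatter is anticipated in either direction. The estimated value for compound 4 is 220 mL.min-1.g-1 in an expected range from 125 mL.min-1.g-1 to 380 mL.min-1.g-1 in this assay for now.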

Compound 4, intrinsic clearance in microsomes: 63.5 mL.min-1.g-1
Beside the measured number, compound 4's estimate is 3.5-fold (0.54 log units) above it; the whole stated range lies above it.
By their numbers in this assay, from the lowest: compound 2; then compound 4; then compounds 1 and 3 (each within the scatter of the next).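

The phenyl ring of the shared core proved sensitive to a single halogen in this assay: fluoro in place of hydrogen had left the number within the scatter, with a 1.0-fold higher number from compound 1 to compound 3 (0.02 log units; within the scatter), whereas chloro on an aromatic carbon, meta to a large group, gave a 3.4-fold lower number from compound 3 to compound 4 (0.53 log units; beyond the scatter). The identity of the halogen therefore matters at this place, as the direct exchange shows with a 3.3-fold lower number from compound 1 to compound 4 (0.51 log units; beyond the scatter), so the fluoro case did not carry over to chloro. The single chlorine also covers part of the distance to the 4-cyanophenoxy compound without closing it, since a 2.1-fold higher number from compound 2 to compound 4 (0.31 log units; beyond the scatter) still lies beyond the scatter, and so a change of one atom on the phenyl now sits alongside the replacement of the whole aryl group as a way to lower this number.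

The compounds shown leave open whether bromo, methyl, methoxy or trifluoromethyl at the same place would follow chloro or fluoro, and whether chloro elsewhere on the same phenyl would give a comparable step. No evidence at hand gives a reason for the gap between chloro and fluoro at this place.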